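Notes on compound 4 against the three measured compounds

This account rests on a few compounds, and the source may have more. Where it says the series, first, only, none or still open, it means among the compounds named here.

Measured compounds:
compound 1 `O=C(N/N=C/c1ccc(Cl)cc1Cl)Nc1cccc2ccccc12` in a functional assay on the whole organism (strain Swiss albino) with Mus musculus as the target, in the maximal electroshock model, with a stated time of 0.5 h; on this read-out higher numbers stand for an effect only at larger amounts of compound and lower numbers for an effect already at smaller amounts: 100 mg/kg
compound 2 `O=C(N/N=C/c1ccc(Br)cc1)Nc1cccc2ccccc12`: 300 mg/kg
compound 3 `COc1ccc(/C=N/NC(=O)Nc2cccc3ccccc23)cc1`: 300 mg/kg

Compound 3 and compound 2 sit together at the high end of the three numbers, no change at the digits printed from compound 2 to compound 3 (within the scatter). Compound 1 is the only lower one: a 3.0-fold higher number from compound 1 to compound 3 (0.48 log units; beyond the scatter) and a 3.0-fold higher number from compound 1 to compound 2 (0.48 log units; beyond the scatter).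

Compound 4 `O=C(N/N=C/c1ccc([N+](=O)[O-])cc1)Nc1cccc2ccccc12` differs from compound 3 by nitro in place of methoxy on an aromatic carbon.

Among the compounds with values here, the one step at the same place, no change at the digits printed from compound 2 to compound 3 (within the scatter), is a different swap and lies within the scatter. The other two steps exchange the whole aryl group and cannot be read as an exchange of a single substituent. Within the data shown here, no measured step covers methoxy against nitro. Among the measured compounds shown here, with the only same-place step flat, the expectation for compound 4 is no change beyond the scatter, no change at the digits printed from compound 3 to compound 4 (within the scatter). Compound 4 is therefore estimated at 300 mg/kg, with a range of 150 mg/kg to 600 mg/kg; a result that is only a limit cannot be ruled out.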

Compound 4, minimum effective dose: 300 mg/kg
Compound 4: the middle estimate sits on the measured number at the digits printed; the range from low to high includes it.
By their numbers in this assay, from the lowest: compound 1; then compounds 2, 3 and 4 (each within the scatter of the next).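

At this place, an aromatic carbon para to a large group, nitro now joins methoxy and bromo in this assay, with no change at the digits printed from compound 3 to compound 4 (within the scatter) and no change at the digits printed from compound 2 to compound 4 (within the scatter) for the two exchanges. Where the earlier compounds offered a single flat exchange at this place, three substituents now give numbers within the scatter of one another, so the flat result extends to nitro. No data on hand bear on why these numbers coincide.

Within the data shown here, compound 1, with 2,4-dichlorophenyl, gives 100 mg/kg and remains the only number apart from the others, and it is open whether a single chloro at this place would share that number or stay with compounds 2, 3 and 4. Also open, on these data alone, is whether an amine or a carboxylic acid at this place would leave the number unmoved.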